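The source may hold more compounds than are shown below. What is called first, only, known or untested is meant among the compounds shown, and "the series" means these compounds.

Compound 1 `O=C(NCCNS(=O)(=O)c1ccc(-c2ccccc2O[C@H]2CC[C@H](O)CC2)s1)Nc1cc(C(F)(F)F)cc(C(F)(F)F)c1`: 10100 nM
Compound 2 `Nc1ccc(Oc2ccccc2-c2ccc(S(=O)(=O)NCCNC(=O)Nc3cc(C(F)(F)F)cc(C(F)(F)F)c3)s2)cc1`: 11900 nM

In a functional assay on RS4-11 cells (Homo sapiens) for inhibition, read by CCK-8 assay, with a stated time of 48 h (a lower number here means a stronger inhibitor, a higher number a weaker inhibitor), compound 2 gives 11900 nM, which lies within the scatter of compound 1 at 10100 nM, so the two stand level. Compound 3 `O=C(NCCNS(=O)(=O)c1ccc(-c2ccccc2Oc2ccc(O)c(O)c2)s1)Nc1cc(C(F)(F)F)cc(C(F)(F)F)c1` keeps the rest of compound 2 and differs at one place: 3,4-dihydroxyphenyl in place of 4-aminophenyl on an oxygen on an aromatic ring. In words, 3,4-dihydroxyphenyl stands in place of 4-aminophenyl on an oxygen on an aromatic ring. Going by the values given here, one measured step bears on this, since it also exchanges the group on that oxygen: a 1.2-fold higher number from compound 1 to compound 2 (0.07 log units; within the scatter). Among the compounds with values here, no measured step shows what the 3,4-dihydroxyphenyl group itself does, so the expectation is weak and no direction can be given. A step beyond the scatter is not expected. The estimated step is a 1.2-fold lower number from compound 2 to compound 3 (0.08 log units; within the scatter). For compound 3 the estimated value is 10000 nM, with an expected range from 3500 nM to 28000 nM.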

Compound 3, half-maximal inhibitory concentration: 4900 nM
Compound 3: middle estimate off by 2.0-fold (0.31 log units), on the high side; low and high end bracket the measured number.
By their numbers in this assay, from the lowest: compound 3; then compounds 1 and 2 (each within the scatter of the next).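

The group on this oxygen does affect the result in this assay: 3,4-dihydroxyphenyl in place of 4-aminophenyl gives a 2.4-fold lower number from compound 2 to compound 3 (0.39 log units; beyond the scatter) and in place of 4-hydroxycyclohexyl gives a 2.1-fold lower number from compound 1 to compound 3 (0.31 log units; beyond the scatter), whereas the earlier exchange at this place stayed within the scatter. A six-membered aromatic ring of carbon only is not enough on its own, as 4-aminophenyl also has one and compound 2 stands level with compound 1; among these three compounds, the lower number appears only with 3,4-dihydroxyphenyl. No measurement shown here accounts for this difference.

As far as these compounds go, whether both hydroxyl groups are needed remains open, and a 3-hydroxyphenyl or 4-hydroxyphenyl group would test this. From the compounds shown here alone, it is also open whether a 3,4-dimethoxyphenyl group or a phenyl ring bearing a carboxylic acid would keep the lower number.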